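Three Benzyl Triazoles at the Assay Limit, a Fourth Expected

The source may hold more compounds than are shown below. What is called first, only, known or untested is meant among the compounds shown, and "the series" means these compounds.

Compound 1, `O=C(OCc1ccccc1)N1CCN(C(=S)SCc2cn(Cc3ccc(Cl)cc3)nn2)CC1`, in a functional assay on PC-3 cells (Homo sapiens) for inhibition, read by MTT assay, with a stated time of 72 h (a higher number here means a weaker inhibitor, a lower number a stronger inhibitor), gives > 128000 nM, which is a limit of the assay and not a number. Compound 2, `O=C(OCc1ccccc1)N1CCN(C(=S)SCc2cn(Cc3ccc(F)cc3)nn2)CC1`, in this assay gives > 128000 nM, again a limit of the assay. Compound 3, `O=C(OCc1ccccc1)N1CCN(C(=S)SCc2cn(Cc3ccc(Cl)c(Cl)c3)nn2)CC1`, in this assay gives > 128000 nM, likewise a limit of the assay.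

Compound 3 therefore stands where every measured compound in this small set stands: the limit of > 128000 nM in this assay, at which 3 of the 3 values shown sit. Because all three values are limits, none of the steps among them can be read. The change of halogen gives a step that the two limits leave unreadable from compound 1 to compound 2, and the added chloro gives a step that the two limits leave unreadable from compound 1 to compound 3. The swap of one benzyl group for another at the same place gives a step that the two limits leave unreadable from compound 2 to compound 3.

Compound 4, `O=C(OCc1ccccc1)N1CCN(C(=S)SCc2cn(Cc3ccccc3Cl)nn2)CC1`, differs from compound 3 by 2-chlorophenyl in place of 3,4-dichlorophenyl on a saturated chain carbon bound to an aromatic nitrogen. The closest comparison is the benzyl swap between compound 2 and compound 3, which lies entirely at the limit, so no readable size or direction is available for the new change. Compound 4 is accordingly expected to remain at the limit of this assay as well, with an estimated step that the limit leaves unreadable from compound 3 to compound 4. The estimate for compound 4 is 160000 nM, with a range from 50000 nM to 600000 nM.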

Compound 4, half-maximal inhibitory concentration: > 128000 nM
Compound 4: a limit, no number; the forecaster's own chance of this, stated with the estimate: 85%; the middle value lies beyond the limit too.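

In this assay compound 4 gives > 128000 nM, again a limit of the assay and not a number. Within the data shown here, no step from compound 1, compound 2 or compound 3 to compound 4 can be read, and all four compounds stand at the same place: the limit of > 128000 nM in this assay, at which 4 of the 4 values shown sit. The compounds shown leave open whether any benzyl group on the shared core gives a readable value in this assay.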